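The source may hold more compounds than are shown below. What is called first, only, known or untested is meant among the compounds shown, and "the series" means these compounds.

Of the compounds shown here, three sharing one core have been measured so far in an assay on isolated protein for inhibition of kallikrein-7 (Homo sapiens), read by fluorescence, with stated times of 10 min and 30 min; a lower number here means a stronger inhibitor, a higher number a weaker inhibitor. Compound 1, `CC1=NC(c2cn(S(=O)(=O)c3ccc(C)cc3)c3ccccc23)CN1`, gives 10000 nM. Compound 2, `CC1=NC(c2cn(S(=O)(=O)c3ccc(Cl)cc3)c3ccc(Br)cc23)CN1`, gives 4700 nM. Compound 3, `CC1=NC(c2cn(S(=O)(=O)c3ccc(F)cc3)c3ccc(C)cc23)CN1`, gives 9400 nM. Compound 3 stands between the other two; its number sits close to that of compound 1 and somewhat under that of compound 2, but each of these gaps lies within the usual scatter of this assay, so no ranking among the three can be drawn from these values.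

Compound 4, `CC1=NC(c2cn(S(=O)(=O)c3ccccc3C)c3ccc(C)cc23)CN1`, is not yet measured. It differs from compound 3 in a single place: 2-methylphenyl in place of 4-fluorophenyl on a sulfonyl sulfur. The group that leaves and the group that enters have the same count of heavy atoms, both carry one six-membered aromatic ring of carbon only, and neither has a hydrogen-bond donor or acceptor. Within the data shown here, no pair of measured compounds shows what a change of this kind does on this core, so the direction of the step is not known from the numbers. Given that the three measured compounds all fall within the scatter of one another, the step is expected to stay within the scatter as well, with a 1.0-fold lower number from compound 3 to compound 4 (0.02 log units; within the scatter) as the estimated step. Compound 4 is expected to give about 9000 nM in this assay, somewhere between 4000 nM and 20000 nM.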

Compound 4, half-maximal inhibitory concentration: 1000 nM
Beside the measured number, compound 4's estimate is 9.0-fold (0.95 log units) above it; measured number outside the range, below it.
By their numbers in this assay, from the lowest: compound 4; then compounds 2, 3 and 1 (each within the scatter of the next, the first and the last beyond it).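

The group on the sulfonyl sulfur is not a silent place on this core: in this assay, putting 2-methylphenyl in place of 4-fluorophenyl gives a 9.4-fold lower number from compound 3 to compound 4 (0.97 log units; beyond the scatter), a step that clears the usual scatter of the assay. The two groups match in their count of heavy atoms, in their one six-membered aromatic ring of carbon only and in having no hydrogen-bond donors or acceptors, so these counts alone do not tell what a group at this place will do. Nothing measured here explains the size of this step.

As far as these compounds go, this single swap both removes the fluorine and brings in the methyl, so it remains open whether 2-chlorophenyl, 2-methoxyphenyl or plain phenyl on the sulfonyl sulfur would hold the lower number. Also open, from the compounds shown here alone, are whether 2-methylphenyl would give a similar step on the core of compound 2, which carries bromine, and what an amine or a carboxylic acid on this aromatic ring would do.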